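Shortening the Chain on the Ring Nitrogen

This account rests on a few compounds, and the source may have more. Where it says the series, first, only, none or still open, it means among the compounds named here.

The measured compounds are:

compound 1, `O=C(NCCCCc1ccccc1)n1c2c(oc1=O)CNCC2`, 340 nM
compound 2, `CC(C)CN1CCC(c2ccc3c(c2)oc(=O)n3C(=O)NCCCCc2ccccc2)CC1`, 120 nM
compound 3, `CN1CCC(c2cc3oc(=O)n(C(=O)NCCCCc4ccccc4)c3cc2F)CC1`, 24 nM

All three were tested in an assay on HEK293 cells for inhibition of acid ceramidase (Homo sapiens), read by fluorescence, with stated times of 10 min and 3 h; a lower number here means a stronger inhibitor, a higher number a weaker inhibitor. Compound 2 stands second highest of the three numbers. Its nearest neighbour is compound 1, whose higher number lies beyond the usual scatter, so compound 2 is the stronger inhibitor of the two. Compound 3 gives a lower number, also beyond the scatter, so compound 3 is the strongest of the three. The compounds differ from each other in more than one place, so no single change among them can be isolated.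

Compound 4, `CCN1CCC(c2ccc3c(c2)oc(=O)n3C(=O)NCCCCc2ccccc2)CC1`, has not yet been measured. It differs from compound 2 in one place: methyl in place of isopropyl on a saturated chain carbon bound to an amine nitrogen in a ring. Cut one bond further out, the change reads isobutyl to ethyl on the amine nitrogen of the ring.

Going by the values given here, no single-change step between measured compounds exists to guide the size of this step. Compound 3, which carries a methyl on the ring nitrogen, gives the lowest number, but it also carries a fluorine that compound 2 lacks, so that comparison is not clean. A modest step toward a lower number is expected for compound 4, possibly within the scatter: a 1.5-fold lower number from compound 2 to compound 4 (0.18 log units; within the scatter). The estimate for compound 4 is 80 nM, with a range from 30 nM to 250 nM.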

Compound 4, half-maximal inhibitory concentration in the acid ceramidase assay: 92 nM
The estimate for compound 4 lay 1.2-fold (0.06 log units) below the measured number, and the stated range covers the measured number.
By their numbers in the acid ceramidase assay, from the lowest: compound 3; then compounds 4 and 2 (each within the scatter of the next); then compound 1.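

In the acid ceramidase assay, going from isobutyl to ethyl on the amine nitrogen of the ring gives a 1.3-fold lower number from compound 2 to compound 4 (0.12 log units; within the scatter), so the two compounds cannot be told apart as inhibitors and this place accepts the shorter chain without a readable loss. In a physicochemical assay for solubility, read by HPLC, in phosphate buffer, measured as kinetic solubility, with a stated time of 1 h, at pH 7.4, tested at 250 uM (on this read-out lower numbers stand for lower solubility and higher numbers for higher solubility), compound 2 gives < 1000 nM, which is a limit of the assay and not a number. In the physicochemical assay compound 4 gives 198000 nM. This one change therefore separates the two read-outs that the earlier compounds could not speak to, with solubility rising far beyond the scatter while inhibition stays within it: the measured solubility of compound 2, < 1000 nM, and of compound 4, 198000 nM, an at least 190-fold higher number (2.29 log units; beyond the scatter)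

Still open, on these data alone, is how a propyl chain or a cyclopropylmethyl group on this ring nitrogen would read in the acid ceramidase assay and in the physicochemical assay, and so whether solubility climbs gradually as the chain shortens or changes abruptly. Compound 3 carries a methyl on the ring nitrogen but also a fluorine that compound 2 and compound 4 lack, so the effect of the methyl alone cannot be read from it.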